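Methoxy in Place of Phenyl on a Shared Core

A few compounds are considered here, and "the series" means these few. Any claim that something is new, unique, unknown or untested is made for them only; others in the source may bear on it.

Three compounds built on one core were compared in a functional assay on T47D cells (Homo sapiens) for inhibition, read by sulforhodamine B assay, with a stated time of 48 h, tested at 10 uM; on this read-out lower numbers stand for less inhibition of growth and higher numbers for more inhibition of growth at the one concentration tested. Compound 2 `CC(=O)c1cccc(Nc2ccnc(SCC(=O)c3ccc(-c4ccccc4)cc3)n2)c1` gives 49%, the lowest of the three numbers. Its nearest neighbour is compound 1 `CCOC(=O)c1ccc(Nc2ccnc(SCC(=O)c3ccc([N+](=O)[O-])cc3)n2)cc1`, which gives 60%, a number higher by more than the scatter, and the furthest is compound 3 `CC(=O)c1ccc(Nc2ccnc(SCC(=O)c3ccc(Cl)cc3)n2)cc1`, which gives 71%, also beyond the scatter. Compound 4 `COc1ccc(C(=O)CSc2nccc(Nc3cccc(C(C)=O)c3)n2)cc1` is not yet measured and differs from compound 2 in one place: methoxy in place of phenyl on an aromatic carbon. Going by the values given here, no pair of measured compounds separated by a single change exists, so the size of this step is uncertain. Because compound 1 gives 60% and compound 3 gives 71%, both above compound 2, a small rise, possibly within the scatter, is expected. Compound 4 is expected to give 54%, between 32% and 74%. This estimate means a step from a number 5 percentage points higher from compound 2 to compound 4 (within the scatter).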

Compound 4, percent growth inhibition at one concentration: 45%
The estimate for compound 4 lay 9 percentage points above the measured number, and the stated range covers the measured number.
By their numbers in this assay, from the lowest: compounds 4 and 2 (each within the scatter of the next); then compound 1; then compound 3.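

In this assay, going by these compounds alone, the replacement of phenyl by methoxy on an aromatic carbon, para to a large group, gives the first step that can be read on the shared core, a number 4 percentage points lower from compound 2 to compound 4 (within the scatter). At this position, therefore, a six-membered aromatic ring of carbon only can give way to a smaller group with one hydrogen-bond acceptor while the two numbers stay within the scatter of each other. Nothing available accounts for this result. Going by these compounds, whether an amine or a carboxylic acid at this position would leave the number within the scatter remains open. So does whether a longer chain on the oxygen would do so.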